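The source may hold more compounds than are shown below. What is called first, only, known or untested is meant among the compounds shown, and "the series" means these compounds.

Measured compounds:
compound 1 `O=C(Nc1ccc(Cl)c(-c2nnc3c(Cl)cccn23)c1)c1ccc(C(F)(F)F)cc1F` — in a functional assay on MCF7 cells (Homo sapiens) for antiproliferative activity, read by MTT assay, with a stated time of 72 h (a lower number here means a stronger inhibitor, a higher number a weaker inhibitor), compound 1 gives 62800 nM
compound 2 `O=C(Nc1ccc(Cl)c(-c2nnc3c(Cl)cccn23)c1)c1cccc(Cl)c1` — compound 2 gives 71900 nM
compound 3 `O=C(Nc1ccc(Cl)c(-c2nnc3c(Cl)cccn23)c1)c1c(F)cccc1Cl` — compound 3 returns only a limit, > 100000 nM

All three share one core and differ only in the aryl group on the carbonyl carbon. Compound 2 has the highest of the two numbers read in this assay; compound 1 sits within the scatter of it, so no order between the two is claimed. The step of an at least 1.3-fold higher number from compound 2 to compound 3 (0.14 log units; that floor lies within the scatter) ends at a limit (the limit of > 100000 nM in this assay, at which 1 of the 3 values shown sits), so its size is known only as a floor.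

Compound 4 `CS(=O)(=O)c1ccc(C(=O)Nc2ccc(Cl)c(-c3nnc4c(Cl)cccn34)c2)cc1` is not yet measured. It differs from compound 2 by 4-(methylsulfonyl)phenyl in place of 3-chlorophenyl on a carbonyl carbon. Within the data shown here, no measured step covers this replacement; the only step from compound 2 changes the same aryl group to a different one and reaches only a floor. With nothing pointing in either direction, a change no larger than the scatter is expected, that is a 1.0-fold lower number from compound 2 to compound 4 (0.01 log units; within the scatter). Compound 4 is therefore estimated at 70000 nM, within 30000 nM to 150000 nM.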

Compound 4, half-maximal inhibitory concentration: 94200 nM
Compound 4: middle estimate off by 1.3-fold (0.13 log units), on the low side; measured number inside the range.
By their numbers in this assay, from the lowest: compounds 1, 2 and 4 (each within the scatter of the next). At a limit, above all of these: compound 3.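

In this assay, 4-(methylsulfonyl)phenyl in place of 3-chlorophenyl on a carbonyl carbon gives a step that can be read as a full size: a 1.3-fold higher number from compound 2 to compound 4 (0.12 log units; within the scatter). This replacement adds hydrogen-bond acceptors where 3-chlorophenyl has none, and the step still stays within the scatter, so this one change gives no evidence that the number at this position responds to them. The step of an at least 1.0-fold lower number from compound 3 to compound 4 (0.02 log units; that floor lies within the scatter) cannot be read as a full size, because it starts from a limit and not a number: the limit of > 100000 nM in this assay, at which 1 of the 4 values shown sits.

Going by these compounds, whether an amine, a carboxylic acid or a longer chain on this aryl group would move the number beyond the scatter remains open. Also open is whether a change in the shared core, which all the compounds shown keep, would shift the number more than changes to the aryl group do.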